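Piperazine ring variation on a sulfonamide ghrelin agonist core

This account rests on a few compounds, and the source may have more. Where it says the series, first, only, none or still open, it means among the compounds named here.

Three compounds share a core that carries a methoxy group and a sulfonamide-bearing fused ring system, and differ in the saturated diamine ring and in the aryl group on the sulfonyl. In a functional assay for agonist activity at growth hormone secretagogue receptor type 1 (Homo sapiens), read by FLIPR (a higher number here means that more compound is needed for the effect, a lower number that less compound is needed), compound 1 `COc1cc2c(cc1N1C[C@@H](C)N(C)[C@@H](C)C1)N(S(=O)(=O)c1ccc3ccccc3c1)CC2` gives 39.8 nM, compound 2 `COc1cc2c(cc1N1C[C@@H](C)N[C@@H](C)C1)N(S(=O)(=O)c1ccc(-c3ccccn3)cc1)CC2` gives 0.2 nM, and compound 3 `COc1cc2c(cc1N1CCN[C@@H](C)C1)N(S(=O)(=O)c1ccc(-c3ccccn3)s1)CC2` gives 3.16 nM. Compound 3 thus stands second highest of the three numbers: compound 1 sits at a higher number, and compound 2 at a lower one, both gaps well beyond the scatter of this assay.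

Compound 4 `COc1cc2c(cc1N1C[C@H](C)NC(C)(C)C1)N(S(=O)(=O)c1ccc(-c3ccccn3)s1)CC2` is the next compound, and it differs from compound 3 in one place: a group of 9 heavy atoms (7 carbon, 2 nitrogen; one six-membered non-aromatic ring with 2 hetero atoms) in place of a group of 7 heavy atoms (5 carbon, 2 nitrogen; one six-membered non-aromatic ring with 2 hetero atoms), on an aromatic carbon. The change adds carbon to the ring that is already present, without altering the donor or acceptor count.

Going by the values given here, no measured pair isolates this particular change, so its effect cannot be read off directly. Compound 2, which also carries a more substituted ring of this kind on a different aryl group, gives 0.2 nM, which leaves room for a small gain but no firm basis for one. Compound 4 is therefore expected to land near compound 3, with an estimated step of a 1.3-fold lower number from compound 3 to compound 4 (0.10 log units; within the scatter) that may well fall within the scatter.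

The estimate for compound 4 in this assay is 2.5 nM, with a range from 0.6 nM to 10 nM.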

Compound 4, half-maximal effective concentration: 0.794 nM
Compound 4: the middle estimate sits 3.1-fold (0.50 log units) above what was measured; low and high end bracket the measured number.
By their numbers in this assay, from the lowest: compound 2; then compound 4; then compound 3; then compound 1.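

Going by these compounds alone, with this pair, the ring on the aromatic carbon ortho to a methoxy group can be read on its own for the first time, with the aryl group on the sulfonyl held fixed. In this assay, the group of 9 heavy atoms in place of the 3-methylpiperazin-1-yl group brings a 4.0-fold lower number from compound 3 to compound 4 (0.60 log units; beyond the scatter), so added carbon on this ring is tolerated here and the number moves down by a modest step beyond the scatter, with the counts of hydrogen-bond donors and acceptors unchanged. Nothing at hand gives a measured basis for the direction or size of this step.

This single pair does not separate the contributions of the added carbons from any contribution of the ring's defined stereocentre, and it does not show whether the same step would appear with another aryl group on the sulfonyl. As far as these compounds go, how an unsubstituted piperazine, a morpholine or a ring bearing an ethyl group would compare at this position also remains open.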